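Cytotoxicity notes: tert-butyl in place of imidazolyl

The compounds below may be only part of what the source reports. "The series", "measured", "known", "first", "only" and "open" are said of these compounds alone.

Measured so far:
- compound 1, `O=C(/C=C/c1ccc([N+](=O)[O-])s1)c1ccc(-n2ccnc2)cc1`; in an ADME assay on THP-1 cells (Homo sapiens) for cytotoxicity, read by resazurin assay, with a stated time of 72 h (a higher number here means that more compound is tolerated, a lower number that less compound is tolerated), compound 1 gives 23400 nM.
- compound 2, `CN(C)c1ccc(/C=C/C(=O)c2ccc(-c3ccccc3)cc2)cc1`; in this assay compound 2 gives only a limit, > 50000 nM.

For the measured compounds named here, compound 1 is the only compound of the pair with a real number in this assay. The value for compound 2 is a limit and not a number, which is the limit of > 50000 nM in this assay, at which 1 of the 2 values shown sits; so compound 1 cannot be ranked against compound 2 beyond saying that compound 2 stayed at the limit while compound 1 gave a number.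

Compound 3, `CC(C)(C)c1ccc(C(=O)/C=C/c2ccc([N+](=O)[O-])s2)cc1`, is not yet measured. It differs from compound 1 by tert-butyl in place of 1H-imidazol-1-yl on an aromatic carbon, para to a large group. The rest of the shared core of compound 1 is kept unchanged.

Going by the values given here, no step between two measured compounds touches this position, so there is nothing to calibrate the size of the change against. The expectation is a step from compound 1 to compound 3 in this assay of a 1.2-fold lower number from compound 1 to compound 3 (0.07 log units; within the scatter), which is taken to lie within the usual scatter rather than beyond it. Compound 3 is accordingly expected to give about 20000 nM in this assay, with a plausible range from 7000 nM to 60000 nM.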

Compound 3, half-maximal cytotoxic concentration: 8400 nM
Estimate against measurement, compound 3: 2.4-fold (0.38 log units) above; low and high end bracket the measured number.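

In this assay the exchange of 1H-imidazol-1-yl for tert-butyl on an aromatic carbon, para to a large group, gives a 2.8-fold lower number from compound 1 to compound 3 (0.44 log units; beyond the scatter). For the compounds shown here, this is the first step read at this position, and it shows that the position is not silent in this read-out: with the rest of the shared core unchanged, the group here alone moves the number beyond the scatter, though only modestly. The direction is also new, with less compound tolerated when tert-butyl replaces the five-membered aromatic ring, but this exchange removes the ring, both nitrogen atoms and both hydrogen-bond acceptors at once, and nothing shown separates these parts or gives a cause for the step.

Compound 2 differs from the others in more than one place and gives a limit and not a number: the limit of > 50000 nM in this assay, at which 1 of the 3 values shown sits. On these data alone, it remains open whether an amine, a carboxylic acid, a methyl group or a longer alkyl chain at this position would stay with compound 1 or with compound 3, and whether the step would hold on a different core.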